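This account rests on a few compounds, and the source may have more. Where it says the series, first, only, none or still open, it means among the compounds named here.

Measured so far:
compound 1 `COc1ccccc1/C=C/C(=O)OC/C=C/c1cc(OC)c(OC)cc1OC`: 100%
compound 2 `COc1cc(OC)c(OC)cc1/C=C/COC(=O)/C=C/c1cc(OC)c(OC)c(OC)c1OC`: 75%

In a functional assay on the whole organism (strain Kunming) with Mus musculus as the target, with a stated time of 0.5 h, at a dose of 100 mg/kg by the intraperitoneal route (on this read-out higher numbers stand for a weaker effect at the one dose given and lower numbers for a stronger effect), compound 1 gives 100%, the higher of the two numbers. Compound 2 gives 75%, lower by a margin beyond the scatter. Compound 3 `COc1cc(OC)c(OC)cc1/C=C/COC(=O)/C=C/c1ccccc1Cl` remains unmeasured; it differs from compound 1 in one place: chloro in place of methoxy on an aromatic carbon. Within the data shown here, no step between measured compounds covers this change, so its size cannot be read from the set. The expected step is a number 12 percentage points lower from compound 1 to compound 3 (beyond the scatter), small, at most a little beyond the scatter, towards a lower number if anything. For compound 3 the estimate in this assay is 88%, between 55% and 100%.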

Compound 3, a percentage reported as activity, at one dose (the size of the read-out at that dose, not a potency): 100%
Estimate against measurement, compound 3: 12 percentage points below; measured number inside the range.
By their numbers in this assay, from the lowest: compound 2; then compounds 1 and 3 (each within the scatter of the next).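

In this assay, among these compounds, the change from 2-methoxyphenyl to 2-chlorophenyl gives no change at the digits printed from compound 1 to compound 3 (within the scatter) and is the first single-place step. At this position, ortho to a large group, the methoxy group can therefore be exchanged for chloro without a read-out change beyond the scatter. No measurement here accounts for this result.

Still open, from the compounds shown here alone, is whether an amine, a carboxylic acid or a longer alkoxy chain at this position would shift the read-out. Also open, going by these compounds, is whether the same exchange gives the same step on other carbons of this ring.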